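Positional bromine isomers on the benzylsulfanyl group

The source may report more compounds than this note shows. Statements on the series, on what has been measured and on what is new or still open speak of the compounds shown alone.

Measured so far:
compound 1 `Cc1cc(N2CC[C@@H](C)[C@@H](N(C)c3ncnc4[nH]ccc34)C2)n2nc(SCc3ccccc3)nc2n1` — 5870 nM
compound 2 `Cc1cc(N2CC[C@@H](C)[C@@H](N(C)c3ncnc4[nH]ccc34)C2)n2nc(SCc3ccccc3Br)nc2n1` — 27000 nM

In a functional assay on MGC-803 cells (Homo sapiens) for inhibition, read by MTT assay, with a stated time of 72 h (on this read-out higher numbers stand for weaker inhibition and lower numbers for stronger inhibition), compound 2 gives the higher of the two numbers, standing a 4.6-fold higher number from compound 1 to compound 2 (0.66 log units; beyond the scatter). Within the data shown here, the only measured step is bromo in place of hydrogen on an aromatic carbon, and it moved the number in the weaker direction by a modest but clear amount.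

Compound 3 `Cc1cc(N2CC[C@@H](C)[C@@H](N(C)c3ncnc4[nH]ccc34)C2)n2nc(SCc3ccc(Br)cc3)nc2n1` differs from compound 2 by 4-bromophenyl in place of 2-bromophenyl on a saturated chain carbon bound to a sulfur. Among the measured compounds shown here, no measured pair shows a bromine moved from one aromatic carbon to another, so the step from compound 1 to compound 2 bears on it only indirectly: it shows that adding bromine on this ring costs inhibition, but not whether the 4-position costs the same. The expected step of a 1.8-fold lower number from compound 2 to compound 3 (0.26 log units; within the scatter) is therefore small and uncertain, with the number of compound 3 expected to stay near that of compound 2. Compound 3 is estimated at 15000 nM, within 4000 nM to 50000 nM.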

Compound 3, half-maximal inhibitory concentration: 4020 nM
The estimate for compound 3 lay 3.7-fold (0.57 log units) above the measured number, and the stated range covers the measured number.
By their numbers in this assay, from the lowest: compounds 3 and 1 (each within the scatter of the next); then compound 2.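

In this assay, the place of the bromine on the benzylsulfanyl ring decides the outcome: with the same atoms joined differently, 4-bromophenyl in place of 2-bromophenyl gives a clear shift toward stronger inhibition (a 6.7-fold lower number from compound 2 to compound 3 (0.83 log units; beyond the scatter)). The loss seen earlier therefore belongs to 2-bromophenyl and not to bromine on this ring as such, since 4-bromophenyl cannot be told apart from the unsubstituted phenyl (a 1.5-fold lower number from compound 1 to compound 3 (0.16 log units; within the scatter)). Nothing available here explains why the two bromine isomers differ.

Going by these compounds, whether the same contrast holds for other halogens remains open, as 2-chlorophenyl and 4-chlorophenyl would show. Also open, on these data alone, is whether a group other than a halogen, such as the methoxy in 4-methoxyphenyl, would fall near compound 1 and compound 3 or move away from them.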